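The compounds below may be only part of what the source reports. "The series", "measured", "known", "first", "only" and "open" are said of these compounds alone.

Of the compounds shown here, three of one series have been tested in a functional assay on SMMC-7721 cells (Homo sapiens) for antiproliferative activity, read by MTT assay, with a stated time of 72 h; on this read-out lower numbers stand for stronger inhibition and higher numbers for weaker inhibition. Compound 1 `Cc1nn(C)c(Oc2ccc(Cl)cc2)c1/C=N\OCc1c(Cl)c(-c2ccc(F)cc2)nn1C` gives 7970 nM in this assay. Compound 2 `Cc1ccc(Oc2c(/C=N\OCc3c(Cl)c(-c4ccc(F)cc4)nn3C)c(C)nn2C)cc1` gives 5230 nM in this assay, and compound 3 `Cc1nn(C)c(Oc2ccc(Cl)cc2)c1/C=N\OCc1c(Cl)c(-c2ccc(Cl)cc2)nn1C` gives 6820 nM in this assay. On these numbers compound 3 stands second highest of the three, with compound 1 nearest and compound 2 furthest, both within the scatter of it, so no order among the three can be read from them.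

The next compound, compound 4 `COc1ccc(Oc2c(/C=N\OCc3c(Cl)c(-c4ccc(Cl)cc4)nn3C)c(C)nn2C)cc1`, differs from compound 3 in one place: methoxy in place of chloro on an aromatic carbon. Of the measured steps, a 1.5-fold lower number from compound 1 to compound 2 (0.18 log units; within the scatter) is the one that bears on this change, since it also exchanges the chloro on the same phenoxy ring for a small group without a charge; it stayed within the scatter. The other step, a 1.2-fold lower number from compound 1 to compound 3 (0.07 log units; within the scatter), touches a different ring and also stayed within the scatter.

On that basis compound 4 is expected to sit close to compound 3 in this assay, with no step beyond the scatter in either direction; the step from compound 3 to compound 4 is estimated as a 1.1-fold lower number from compound 3 to compound 4 (0.06 log units; within the scatter). The estimate for compound 4 in this assay is 6000 nM, with a range from 3000 nM to 12000 nM.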

Compound 4, half-maximal inhibitory concentration: 760 nM
Estimate against measurement, compound 4: 7.9-fold (0.90 log units) above; the measured number lies below the stated range.
By their numbers in this assay, from the lowest: compound 4; then compounds 2, 3 and 1 (each within the scatter of the next).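

In this assay, going from 4-chlorophenoxy to 4-methoxyphenoxy gives a 9.0-fold lower number from compound 3 to compound 4 (0.95 log units; beyond the scatter), the only step shown so far that lies beyond the scatter. It shows that the number is not indifferent to what stands on this aromatic carbon: the exchange of chloro for methyl at the same place gave only a 1.5-fold lower number from compound 1 to compound 2 (0.18 log units; within the scatter) and stayed within the scatter, whereas methoxy, which carries a hydrogen-bond acceptor that chloro lacks, moves the number clearly, though the two exchanges were read with different halogens on the other aromatic ring. Nothing available explains this step.

The compounds shown leave open whether the oxygen or the whole methoxy group carries the step, which a hydroxy, an ethoxy or a dimethylamino group at this place could begin to separate. Within the data shown here, they also leave open whether methoxy gives a step of this size with the 4-fluorophenyl group of compound 1 in place of the 4-chlorophenyl group of compound 4, since no pair here reads that exchange in both settings.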